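A Ring Swap on the Carbonyl Carbon and Microsomal Stability

This account rests on a few compounds, and the source may have more. Where it says the series, first, only, none or still open, it means among the compounds named here.

Measured so far:
compound 1 `O=C(NCc1ccc(S(=O)(=O)c2ccccc2)cc1)c1cc2ncccc2s1`: 1.6%
compound 2 `O=C(NCc1ccc(S(=O)(=O)c2cc(F)cc(F)c2)cc1)c1cc2ccncc2o1`: 12%

Of the compounds shown here, two have been measured in an ADME assay on microsomes from liver (Mus musculus) for metabolic stability, read by LC-MS, with a stated time of 30 min, tested at 1 uM; a higher number here means that more of the compound is left, a lower number that less of the compound is left. Compound 1 gives 1.6%, the lowest of the two numbers. Compound 2 gives 12%, a value that lies beyond the usual scatter from the number of compound 1, though both are low. Compound 3 `O=C(NCc1ccc(S(=O)(=O)c2ccccc2)cc1)c1ccc2nncn2c1` has not yet been measured. It differs from compound 1 at a carbonyl carbon whose other neighbours are an amide-type nitrogen: a group of 9 heavy atoms (6 carbon, 3 nitrogen; one five-membered aromatic ring with 3 hetero atoms, one six-membered aromatic ring with 1 hetero atom) in place of a group of 9 heavy atoms (7 carbon, 1 nitrogen, 1 sulfur; one five-membered aromatic ring with 1 hetero atom, one six-membered aromatic ring with 1 hetero atom), on a carbonyl carbon. Among the compounds with values here, no step between measured compounds differing in a single place is available, so the size of this change cannot be read from the data. With both measured numbers low, compound 3 is expected to remain in the low range, with a step of a number 6.4 percentage points higher from compound 1 to compound 3 (within the scatter) expected to be small and, if anything, upward. For compound 3 the estimate in this assay is 8%, with a range from 1% to 30%.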

Compound 3, percent of the compound remaining: 47%
Beside the measured number, compound 3's estimate is 39 percentage points below it; the whole stated range lies below it.
By their numbers in this assay, from the lowest: compound 1; then compound 2; then compound 3.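

In this assay, the carbonyl carbon proves to be a place where the group carried matters greatly: with the rest of compound 1 unchanged, the swap to the group with the five-membered aromatic ring with 3 hetero atoms gives a number 45.4 percentage points higher from compound 1 to compound 3 (beyond the scatter). Both groups hold 9 heavy atoms and a six-membered aromatic ring with 1 hetero atom, so this large step comes without a change in those counts, only with sulfur and carbon leaving and nitrogen entering. Nothing at hand bears on why the number moves.

On these data alone, with a single step at this position, it stays open whether a simpler group there, such as a lone pyridine ring, would do the same. Also open, as far as these compounds go, is whether the swap carries over to the difluorophenyl sulfone of compound 2.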